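The source may hold more compounds than are shown below. What is called first, only, known or untested is meant among the compounds shown, and "the series" means these compounds.

Compound 1 `COc1ccc(C2SCC(=O)N2CCN2CCCCC2)cc1` is the starting point of this small series. In an ADME assay on Vero cells (Chlorocebus sabaeus) for cytotoxicity, read by neutral red uptake, tested at 197 ug/mL (a lower number here means a stronger effect, a higher number a weaker effect of the compound at the concentration tested), compound 1 gives 87%. Compound 2 `O=C1CSC(c2ccc([N+](=O)[O-])cc2)N1CCN1CCCCC1` differs from it by nitro in place of methoxy on an aromatic carbon and gives 72%, a step of a number 15 percentage points lower from compound 1 to compound 2 (beyond the scatter). Compound 3 `COc1ccccc1C1SCC(=O)N1CCN1CCCCC1` has the same atoms as compound 1 joined differently; the difference between the two cores is not broken down here. In this assay compound 3 gives 72%, level with compound 2 within the scatter. Compound 4 `O=C1CSC(c2ccccc2[N+](=O)[O-])N1CCN1CCCCC1` arises from compound 3 by nitro in place of methoxy on an aromatic carbon, the same kind of change as that between compound 1 and compound 2, though here the place is ortho to a large group rather than para to a large group. Because the earlier step was a number 15 percentage points lower from compound 1 to compound 2 (beyond the scatter), a similar lowering is expected, a number 12 percentage points lower from compound 3 to compound 4 (beyond the scatter), with the different place leaving room for a wider range. Compound 4 is therefore estimated at 60%.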

Compound 4, a percentage reported as activity, at one concentration (the size of the read-out at that concentration, not a potency): 100%
Compound 4: the middle estimate sits 40 percentage points below what was measured; measured number outside the range, above it.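

In this assay, nitro in place of methoxy gives a number 28 percentage points higher from compound 3 to compound 4 (beyond the scatter), so the same swap does not carry over from one core to the other, not even in direction: the same change on two cores in this assay, a number 15 percentage points lower (beyond the scatter) from compound 1 to compound 2 and a number 28 percentage points higher (beyond the scatter) from compound 3 to compound 4, 43 percentage points apart, beyond the scatter of two such steps In this series, then, the step measured on one core cannot simply be transferred to the other. Within the data shown here, with only two pairs, this does not show why the steps part, or whether the place on the ring, ortho to a large group in compound 4, is what sets them apart.

The compounds shown leave open how any other group would behave on these two cores. An amine or a carboxylic acid in the same place might follow either step, or neither.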